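This account rests on a few compounds, and the source may have more. Where it says the series, first, only, none or still open, it means among the compounds named here.

Compound 2, with the structure `Cc1cc(Cc2cccnc2)c(=O)n(CC(=O)Nc2ccc(Br)cc2)n1`, is known in a functional assay on HL-60 cells (Homo sapiens), read by calcium flux (on this read-out higher numbers stand for an effect only at larger amounts of compound and lower numbers for an effect already at smaller amounts), only through a limit: in this assay compound 2 gives > 50000 nM, and that figure marks the edge of the measurement rather than a number. Its closest measured neighbour, compound 1 with the structure `Cc1cc(Cc2ccsc2)c(=O)n(CC(=O)Nc2ccc(Br)cc2)n1`, sits at the same limit, giving > 50000 nM in this assay. The step that the two limits leave unreadable from compound 1 to compound 2 therefore cannot be sized, since the limit of > 50000 nM in this assay, at which 2 of the 2 values shown sit, describes where both values sit. Compound 3, with the structure `Cc1cc(Cc2ccc(C(N)=O)cc2)c(=O)n(CC(=O)Nc2ccc(Br)cc2)n1`, carries the change (4-carbamoylphenyl in place of pyridin-3-yl on a saturated chain carbon bound to an aromatic carbon). Within the data shown here, the only measured step that touches this position is the one from compound 1 to compound 2, and it is unreadable, so no direction can be drawn from it. He accordingly expects the step of a number no higher from compound 2 to compound 3 (the limit leaves the size open) to be no larger than what two values at a limit can reveal. Compound 3 is estimated at 50000 nM, between 10000 nM and 100000 nM, with the outcome most likely reported again as a limit.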

Compound 3, half-maximal effective concentration: > 50000 nM
Compound 3 was reported as a limit; the forecaster's own chance of this, stated with the estimate: 70%; the middle value lies on the limit itself.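

In this assay compound 1, compound 2 and compound 3 all stand at a limit, so no step among them can be read: the limit of > 50000 nM in this assay, at which 3 of the 3 values shown sit.

The compounds shown leave open whether any group on the saturated chain carbon bound to an aromatic carbon would give a value readable as a number.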